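The source may report more compounds than this note shows. Statements on the series, on what has been measured and on what is new or still open speak of the compounds shown alone.

Working notes on the series in a physicochemical assay for solubility, in phosphate buffer, with a stated time of 18 h; a higher number here means a more soluble compound, a lower number a less soluble compound: compound 1 `N#Cc1c(N)nc2nc(Cc3ccccc3)ncc2c1N` gives 13000 nM, compound 2 `CC(C)(C)c1nc(CCCCC#N)c2c(N)c(C#N)c(N)nc2n1` gives 16000 nM, and compound 3 `CC(C)(C)c1nc(-c2ccsc2)c2c(N)c(C#N)c(N)nc2n1` gives 40000 nM. Compound 3 therefore has the highest number of the three, and its gaps to compound 1 and compound 2 both lie beyond the scatter.

The next entry is compound 4 `Cc1c[nH]c(-c2nc(C(C)(C)C)nc3nc(N)c(C#N)c(N)c23)n1`, which carries 4-methyl-1H-imidazol-2-yl in place of thiophen-3-yl on an aromatic carbon, next to the ring nitrogen: 4-methyl-1H-imidazol-2-yl in place of thiophen-3-yl on an aromatic carbon.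

Within the data shown here, one measured step bears on this place: a 2.5-fold higher number from compound 2 to compound 3 (0.40 log units; beyond the scatter), with thiophen-3-yl in place of 4-cyanobutyl. Among the measured compounds shown here, that step is modest, and no measured compound carries 4-methyl-1H-imidazol-2-yl, so the data set no direction for the new group. On that single precedent, no step beyond the scatter is expected in this assay, although a modest step either way would not be out of line.

The estimated change is a 1.1-fold lower number from compound 3 to compound 4 (0.06 log units; within the scatter). For compound 4 the expected value is 35000 nM, with an estimated range of 12000 nM to 100000 nM.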

Compound 4, solubility: 5000 nM
Compound 4: middle estimate off by 7.0-fold (0.85 log units), on the high side; measured number outside the range, below it.
By their numbers in this assay, from the lowest: compound 4; then compounds 1 and 2 (each within the scatter of the next); then compound 3.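

Among these compounds, this position can move this assay downward as well as upward: the one earlier step here went up, whereas an 8.0-fold lower number from compound 3 to compound 4 (0.90 log units; beyond the scatter), and a 3.2-fold lower number from compound 2 to compound 4 (0.51 log units; beyond the scatter), both beyond the scatter. The first of these steps exchanges one five-membered aromatic ring for another, so the choice of ring at this position is enough to produce a step beyond the scatter, and compound 4 falls below both the thiophen-3-yl and 4-cyanobutyl compounds. No available measurement explains this fall, and the added ring nitrogen, methyl and hydrogen-bond donor remain counted differences only.

Still open, as far as these compounds go, is whether the methyl on the imidazole contributes, which an unsubstituted imidazol-2-yl group would test. The compounds shown also leave open how an open-chain amine or a carboxylic acid at this position would read in this assay.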